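The source may report more compounds than this note shows. Statements on the series, on what has been measured and on what is new or still open speak of the compounds shown alone.

Compound 1 `COc1cc(/C=C/C(=O)c2cccc(NC(=O)c3ccc(Cl)c(Cl)c3)c2)ccc1O`: 45%
Compound 2 `COc1cc(/C=C/C(=O)c2cccc(N)c2)ccc1O`: 90%
Compound 3 `COc1cc(/C=C/C(=O)c2cccc(NC(=O)c3cc(Cl)cc(Cl)c3)c2)ccc1O`: 58%

In a functional assay on HUVEC cells (Homo sapiens) for inhibition, tested at 10 ug/mL (a higher number here means a stronger effect of the compound at the concentration tested, a lower number a weaker effect), compound 3 gives 58%, the second highest of the three numbers. Compound 1, the nearest, gives 45%. Compound 2, the furthest, gives 90%.

Compound 4 `CCCC(=O)Nc1cccc(C(=O)/C=C/c2ccc(O)c(OC)c2)c1` differs from compound 3 as follows.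

propyl in place of 3,5-dichlorophenyl on a carbonyl carbon

For the measured compounds named here, two measured steps bear on this change. The steps of a number 32 percentage points lower from compound 2 to compound 3 (beyond the scatter) and a number 45 percentage points higher from compound 1 to compound 2 (beyond the scatter) both show that a dichlorophenylcarbonyl on the ring nitrogen of the shared core gives a much lower read-out than the free amine of compound 2. The step of a number 13 percentage points higher from compound 1 to compound 3 (beyond the scatter) shows that exchanging one dichlorophenyl for the other on the carbonyl carbon shifts the number only modestly. Going by the values given here, no measured compound carries a propyl on that carbonyl carbon, so the direction of the step is open. The amide of compound 4 is expected to sit between compound 3 and compound 2, and the estimated step is a number 10 percentage points higher from compound 3 to compound 4 (within the scatter), beyond the scatter. For compound 4 in this assay the estimate is 68%, ranging from 48% to 88%.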

Compound 4, a percentage reported as inhibition, at one concentration (the size of the read-out at that concentration, not a potency): 87%
For compound 4 the middle estimate is 19 percentage points below the measured one, within the range that was stated.
By their numbers in this assay, from the lowest: compound 1; then compound 3; then compounds 4 and 2 (each within the scatter of the next).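

In this assay the low read-outs of the dichlorophenylcarbonyl amides do not follow from acylation of the ring nitrogen as such: propylcarbonyl in place of hydrogen on that nitrogen gives a number 3 percentage points lower from compound 2 to compound 4 (within the scatter) and so leaves the read-out level with the free amine. Propyl in place of either dichlorophenyl on the carbonyl carbon gives a number 29 percentage points higher from compound 3 to compound 4 (beyond the scatter) and a number 42 percentage points higher from compound 1 to compound 4 (beyond the scatter), so here the read-out goes with the group on the carbonyl carbon, not with the amide itself. Among these four compounds only the two dichlorophenyl amides read low, and none goes against that.

Going by these compounds, whether a longer chain or an unsubstituted phenyl on this carbonyl carbon holds the read-out of compound 4 stays open, and so does whether the ring or the chlorines go with the drop. Nothing at hand explains the gap between propyl and dichlorophenyl at this position.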